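Swapping the hydrazone aryl end on two related cores

This account rests on a few compounds, and the source may have more. Where it says the series, first, only, none or still open, it means among the compounds named here.

Compound 1 `CCN(CC)c1ccc(/C=N/NC(=O)Nc2cc3c(Nc4ccc(F)c(Cl)c4)ncnc3cc2O[C@H]2CCOC2)c(O)c1` and compound 2 `O=C(N/N=C/c1ccc(O)cc1)Nc1cc2c(Nc3ccc(F)c(Cl)c3)ncnc2cc1O[C@H]1CCOC1` share one core and differ only at the hydrazone end. In a functional assay on PC-3 cells (Homo sapiens) for cytotoxicity, read by MTT assay, with a stated time of 72 h (a lower number here means a stronger inhibitor, a higher number a weaker inhibitor), compound 1 gives 4590 nM, and compound 2 gives 4890 nM. The change between them is 4-hydroxyphenyl in place of 4-(diethylamino)-2-hydroxyphenyl on a carbon with a double bond to nitrogen and the step it made was a 1.1-fold higher number from compound 1 to compound 2 (0.03 log units; within the scatter). Compound 3 `CCN(CC)c1ccc(/C=N/NC(=O)Nc2cc3c(Nc4ccc(F)c(Cl)c4)ncnc3cc2OC)c(O)c1` carries the same hydrazone end as compound 1 on a second core; the two cores differ by methyl in place of oxolan-3-yl on an oxygen on an aromatic ring. In this assay compound 3 gives 34300 nM, a result that is a 7.5-fold higher number from compound 1 to compound 3 (0.87 log units; beyond the scatter). Compound 4 `COc1cc2ncnc(Nc3ccc(F)c(Cl)c3)c2cc1NC(=O)N/N=C/c1ccc(O)cc1` has not yet been measured in this assay. It differs from compound 3 by 4-hydroxyphenyl in place of 4-(diethylamino)-2-hydroxyphenyl on a carbon with a double bond to nitrogen, the same change as that between compound 1 and compound 2, made at a place described in identical terms on both cores. For compound 4 the expected step is a 1.0-fold higher number from compound 3 to compound 4 (0.02 log units; within the scatter), because a 1.1-fold higher number from compound 1 to compound 2 (0.03 log units; within the scatter) stayed within the scatter when the same change was made on the first core. Compound 4 is therefore estimated at 36000 nM in this assay, with a range of 15000 nM to 90000 nM.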

Compound 4, half-maximal inhibitory concentration: 16600 nM
The estimate for compound 4 lay 2.2-fold (0.34 log units) above the measured number; low and high end bracket the measured number.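

On the core of compound 3, the change to 4-hydroxyphenyl gave a 2.1-fold lower number from compound 3 to compound 4 (0.32 log units; beyond the scatter) in this assay, and this step does not differ measurably from the one on the core of compound 1: the same change on two cores in this assay, a 1.1-fold higher number (0.03 log units; within the scatter) from compound 1 to compound 2 and a 2.1-fold lower number (0.32 log units; beyond the scatter) from compound 3 to compound 4, 2.2-fold (0.34 log units) apart, within the scatter of two such steps. With 4-hydroxyphenyl at the hydrazone end, methyl in place of oxolan-3-yl gave a 3.4-fold higher number from compound 2 to compound 4 (0.53 log units; beyond the scatter), which has the same direction as the step with the other hydrazone end and does not differ measurably from it: the same change on two cores in this assay, a 7.5-fold higher number (0.87 log units; beyond the scatter) from compound 1 to compound 3 and a 3.4-fold higher number (0.53 log units; beyond the scatter) from compound 2 to compound 4, 2.2-fold (0.34 log units) apart, within the scatter of two such steps. Both changes therefore carried from one partner to the other within the scatter among these four compounds, but this rests on a single pair of steps for each change, and it shows neither that they would carry to other cores nor why the numbers move.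

The compounds shown leave open whether a hydrazone end with no hydroxyl group, or with an amine on the phenyl ring other than diethylamino, would follow the same course. They also leave open how a longer chain on the oxygen would compare with methyl and oxolan-3-yl.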